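The source may hold more compounds than are shown below. What is called first, only, known or untested is meant among the compounds shown, and "the series" means these compounds.

Compound 1 `COc1cc(/C=C/C(=O)c2cccc(-n3cc(-c4ccccc4)[nH]c3=O)c2)cc(OC)c1OC`: 1130 nM in a functional assay on HCT-15 cells (Homo sapiens) for inhibition; on this read-out lower numbers stand for stronger inhibition of growth and higher numbers for weaker inhibition of growth
Compound 2 `COc1ccc(-c2cn(-c3cccc(C(=O)/C=C/c4cc(OC)c(OC)c(OC)c4)c3)c(=O)[nH]2)cc1`: 1380 nM

Going by the values given here, compound 2 sits at the high end of the two numbers, but the only step separating it from compound 1 lies within the scatter: a 1.2-fold higher number from compound 1 to compound 2 (0.09 log units; within the scatter).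

Compound 3 `COc1cc(/C=C/C(=O)c2cccc(-n3cc(-c4cc(OC)c(OC)c(OC)c4)[nH]c3=O)c2)cc(OC)c1OC` differs from compound 2 by 3,4,5-trimethoxyphenyl in place of 4-methoxyphenyl on an aromatic carbon. Among the compounds with values here, the one measured step bearing on this, a 1.2-fold higher number from compound 1 to compound 2 (0.09 log units; within the scatter), put a single methoxy onto the same aryl group without movement beyond the scatter. Adding two further methoxy groups is therefore expected to change little: a 1.1-fold higher number from compound 2 to compound 3 (0.04 log units; within the scatter). Compound 3 is estimated at 1500 nM, with a range of 600 nM to 4000 nM.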

Compound 3, concentration for 50% growth inhibition: 1890 nM
The estimate for compound 3 lay 1.3-fold (0.10 log units) below the measured number, and the stated range covers the measured number.
By their numbers in this assay, from the lowest: compounds 1, 2 and 3 (each within the scatter of the next).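

Placing 3,4,5-trimethoxyphenyl on this aromatic carbon of the five-membered ring gives a 1.4-fold higher number from compound 2 to compound 3 (0.14 log units; within the scatter) and, starting from phenyl, a 1.7-fold higher number from compound 1 to compound 3 (0.22 log units; within the scatter) in this assay across the full change. Phenyl, 4-methoxyphenyl and 3,4,5-trimethoxyphenyl thus sit here with no step beyond the scatter, now including the largest of the three groups. Nothing available explains this flat result.

Only methoxy substitution on this phenyl is covered. An amine or a carboxylic acid on that ring, or a longer alkyl chain in place of it, remains an open question.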